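Indolyl Replacement and Cytotoxicity Toward BJ Cells

The source may report more compounds than this note shows. Statements on the series, on what has been measured and on what is new or still open speak of the compounds shown alone.

Compound 1 `CC(C)COc1cccc(-c2ccc(C(=O)N(Cc3cccc(OCCCCCC(=O)O)c3)C(C)C)cc2)c1` reaches only the limit > 26000 nM in an ADME assay on BJ cells (Homo sapiens) for cytotoxicity, read by CellTiter-Glo and resazurin assay, with a stated time of 72 h; on this read-out higher numbers stand for an effect only at larger amounts of compound and lower numbers for an effect already at smaller amounts.
Compound 2 `CC(C)N(Cc1cccc(OCCCCCC(=O)O)c1)C(=O)c1ccc(-c2ccoc2)cc1` likewise stops at the limit > 26000 nM in this assay.
Compound 3 `COc1cccc(-c2ccc(C(=O)N(Cc3cccc(OCCCCCC(=O)O)c3)C(C)C)cc2)c1` stops at the limit > 20900 nM in this assay.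

Compound 3 thus stands at a limit, as do both other measured compounds; none of the three yields a number. The step that the two limits leave unreadable from compound 1 to compound 2 cannot be read, nor can a step that the two limits leave unreadable from compound 1 to compound 3 or a step that the two limits leave unreadable from compound 2 to compound 3. Among the measured compounds shown here, the only evidence is that the limit of > 20900 nM in this assay, at which 1 of the 3 values shown sits, and (the limit of > 26000 nM in this assay, at which 2 of the 3 values shown sit), so no measured step gives a direction or size to build on.

Compound 4 `CC(C)N(Cc1cccc(OCCCCCC(=O)O)c1)C(=O)c1ccc(-c2c[nH]c3ccccc23)cc1` differs from compound 3 by 1H-indol-3-yl in place of 3-methoxyphenyl on an aromatic carbon. For the measured compounds named here, no measured step bears on this change, and the three limits offer no hint of a readable effect in this assay. Compound 4 is therefore expected to behave like compound 3, most likely again at a limit, with an estimated step that the limit leaves unreadable from compound 3 to compound 4. The estimate for compound 4 is 25000 nM, with a range from 12000 nM to 60000 nM.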

Compound 4, half-maximal effective concentration: > 26000 nM
Compound 4 ended at the assay's limit (the forecaster's own chance of this, stated with the estimate: 80%); middle value at least 1.0-fold (0.01 log units) from the limit.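

Compound 4, like compounds 1, 2 and 3, stops at a limit in this assay, so the steps to compound 4 from compounds 1, 2 and 3 cannot be read. The compounds shown leave open at what concentration any of them would register an effect, and whether the groups exchanged among them differ at all.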